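Swapping a Hydroxy for Fluoro on a Phenyl Amide

The source may hold more compounds than are shown below. What is called first, only, known or untested is meant among the compounds shown, and "the series" means these compounds.

Compound 1 `CN(C)C(=O)c1cc2cnc(Nc3ccc(NC(=O)C4(C(=O)Nc5ccc(O)cc5)CC4)cc3)nc2n1C1CCCC1` is the starting point. For the measured compounds named here, in a functional assay on A549 cells (Homo sapiens) for inhibition, read by CCK-8 assay, with a stated time of 72 h, tested at 1 uM (on this read-out higher numbers stand for more inhibition of growth at the one concentration tested and lower numbers for less inhibition of growth), compound 1 gives 93.6%, the highest of the three numbers measured so far. Compound 3 `CN(C)C(=O)c1cc2cnc(Nc3ccc(NC(=O)C4(C(=O)Nc5ccc(C#N)cc5)CC4)cc3)nc2n1C1CCCC1` carries a cyano group in place of the hydroxy; in this assay compound 3 gives 86.1%, and the step of a number 7.5 percentage points lower from compound 1 to compound 3 (within the scatter) lies within the scatter, so the two compounds cannot be ranked. Compound 2 `COc1ccc(NC(=O)C2(C(=O)Nc3ccc(Nc4ncc5cc(C(=O)N(C)C)n(C6CCCC6)c5n4)cc3)CC2)cc1`, with a methoxy group in place of the hydroxy, gives 74.4%; the step of a number 19.2 percentage points lower from compound 1 to compound 2 (beyond the scatter) is a modest drop, and the comparison a number 11.7 percentage points higher from compound 2 to compound 3 (beyond the scatter) is a modest rise.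

Compound 4 `CN(C)C(=O)c1cc2cnc(Nc3ccc(NC(=O)C4(C(=O)Nc5ccc(F)cc5)CC4)cc3)nc2n1C1CCCC1` has not yet been measured. It differs from compound 1 in one place: fluoro in place of hydroxy on an aromatic carbon. Going by the values given here, two measured steps bear on this change. Replacing the hydroxy by cyano, in a number 7.5 percentage points lower from compound 1 to compound 3 (within the scatter), cost little, while adding a methyl to the hydroxy oxygen, in a number 19.2 percentage points lower from compound 1 to compound 2 (beyond the scatter), cost more. Fluoro, like cyano, replaces the hydroxy outright rather than capping it, so a small loss or none beyond the scatter is expected. Compound 4 is therefore estimated at 86%, with a range from 72% to 96%, which means an expected step of a number 7.6 percentage points lower from compound 1 to compound 4 (within the scatter).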

Compound 4, percent growth inhibition at one concentration: 86.6%
The estimate for compound 4 lay 0.6 percentage points below the measured number; measured number inside the range.
By their numbers in this assay, from the lowest: compound 2; then compounds 3, 4 and 1 (each within the scatter of the next).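

Fluoro counts no hydrogen-bond donor and no hydrogen-bond acceptor, whereas the hydroxy it replaces counts one of each, yet this assay gives a number 7 percentage points lower from compound 1 to compound 4 (within the scatter) and so offers no sign that the hydroxy's hydrogen-bond donor is needed at this place on the ring. Fluoro and cyano cannot be told apart here either, with a number 0.5 percentage points higher from compound 3 to compound 4 (within the scatter) as the comparison between them, so three different groups at this position now give numbers that lie within the scatter of the next. The methoxy group stays the exception, as the comparison with fluoro shows a number 12.2 percentage points higher from compound 2 to compound 4 (beyond the scatter) and thus confirms with a second replacement that compound 2 sits apart from the others.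

Going by these compounds, how an amine or a carboxylic acid at this same place on the ring would read remains open, and a reading at one concentration says nothing about how the compounds would compare across a range of concentrations. Nothing among the available data explains why fluoro, cyano and hydroxy read alike while methoxy does not.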